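A Fluoro Added to the Chlorophenyl of Compound 1

A few compounds are considered here, and "the series" means these few. Any claim that something is new, unique, unknown or untested is made for them only; others in the source may bear on it.

Compound 1 `N#CC1=C(N)Oc2c(c3nc4ccccc4nc3c3ccccc23)C12C(=O)N(Cc1cnnn1-c1cccc(Cl)c1)c1ccccc12` gives 43600 nM in a functional assay on MCF7 cells (Homo sapiens) for antiproliferative activity, read by MTT assay, with a stated time of 48 h; on this read-out higher numbers stand for weaker inhibition and lower numbers for stronger inhibition.
Compound 2 `N#CC1=C(N)Oc2c(c3nc4ccccc4nc3c3ccccc23)C12C(=O)N(Cc1cnnn1-c1ccccc1Br)c1ccccc12` reaches only a limit of the assay, > 50000 nM, in this assay.
Compound 3 `Cc1ccc(-n2nncc2CN2C(=O)C3(C(C#N)=C(N)Oc4c3c3nc5ccccc5nc3c3ccccc43)c3ccccc32)c(C)c1` likewise reaches only a limit, > 50000 nM, in this assay.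

Among the compounds with values here, compound 1 thus stands as the only real number in this small set; the other two values are limits, (the limit of > 50000 nM in this assay, at which 2 of the 3 values shown sit). Compound 4 `N#CC1=C(N)Oc2c(c3nc4ccccc4nc3c3ccccc23)C12C(=O)N(Cc1cnnn1-c1ccc(F)c(Cl)c1)c1ccccc12` is the next member, and its difference from compound 1 is fluoro in place of hydrogen on an aromatic carbon. The two measured steps both exchange the whole aryl group on the aromatic nitrogen rather than adding a single atom to it: an at least 1.1-fold higher number from compound 1 to compound 2 (0.05 log units; that floor lies within the scatter) and an at least 1.1-fold higher number from compound 1 to compound 3 (0.05 log units; that floor lies within the scatter), each ending at the limit. Neither step speaks directly to a fluoro placed on the existing 3-chlorophenyl, and the pair of limits gives no readable size. With no evidence for a move in either direction, the expected step is none beyond the scatter: a 1.0-fold higher number from compound 1 to compound 4 (0.01 log units; within the scatter). Compound 4 is therefore estimated at 45000 nM, within a range of 20000 nM to 100000 nM, with a fair chance that only a limit is reported.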

Compound 4, half-maximal inhibitory concentration: > 50000 nM
Compound 4 gave a limit, no number (the forecaster's own chance of this, stated with the estimate: 45%); middle value at least 1.1-fold (0.04 log units) away from the limit.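

Adding a single fluoro to the 3-chlorophenyl, ortho to the chloro group and para to a large group, gives an at least 1.1-fold higher number from compound 1 to compound 4 (0.05 log units; that floor lies within the scatter). Unlike the earlier steps, which replaced the whole aryl group, this one keeps the 3-chlorophenyl in place, yet its floor lies within the scatter, so a real loss of activity and no change at all both remain possible. The value of compound 4 is a limit and not a number, so its steps to compound 2 and compound 3 cannot be read, and the set now rests mostly on limits: the limit of > 50000 nM in this assay, at which 3 of the 4 values shown sit.

On these data alone, how far past its limit compound 4 lies remains open, and with it the true size of the fluoro step. Also open, as far as these compounds go, is whether a methoxy, an amine or a carboxylic acid at this position would give stronger inhibition than compound 1.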